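A few compounds are considered here, and "the series" means these few. Any claim that something is new, unique, unknown or untested is made for them only; others in the source may bear on it.

Measured so far in an in vitro functional assay on 1321-N1 cells for agonist activity at P2Y purinoceptor 6 (Homo sapiens); on this read-out higher numbers stand for an effect only at larger amounts of compound and lower numbers for an effect already at smaller amounts:
compound 1 `CSc1ccn([C@@H]2O[C@H](COP(=O)(O)OP(=O)(O)O)[C@@H](O)[C@H]2O)c(=O)n1` — 2300 nM
compound 2 `O=c1[nH]c(=S)ccn1[C@@H]1O[C@H](COP(=O)(O)OP(=O)(O)O)[C@@H](O)[C@H]1O` — 80 nM

Compound 1 stands highest of the two numbers in this assay; compound 2 sits at a considerably lower value, a gap beyond the scatter. Within the data shown here, no single-change pair among the measured compounds exists.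

Compound 3 `CCSc1ccn([C@@H]2O[C@H](COP(=O)(O)OP(=O)(O)O)[C@@H](O)[C@H]2O)c(=O)n1` differs from compound 1 by methyl in place of hydrogen on a saturated chain carbon bound to a sulfur. Among the measured compounds shown here, with no measured step of this kind, the expected step from compound 1 to compound 3 is a 1.3-fold higher number from compound 1 to compound 3 (0.12 log units; within the scatter), near nothing or a small rise. Compound 3 is thus estimated at 3000 nM, within 1200 nM to 9000 nM.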

Compound 3, half-maximal effective concentration: 280 nM
For compound 3 the middle estimate is 11-fold (1.03 log units) above the measured one; measured number outside the range, below it.
By their numbers in this assay, from the lowest: compound 2; then compound 3; then compound 1.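

Methylsulfanyl to ethylsulfanyl gives an 8.2-fold lower number from compound 1 to compound 3 (0.91 log units; beyond the scatter) in this assay, so this position responds to the addition of a single methyl, by a step beyond the scatter. Among these compounds, the direction is the first information on chain length here, and it rests on this one pair. No measurement at hand accounts for the step.

From the compounds shown here alone, whether propylsulfanyl or a longer chain in place of ethylsulfanyl extends the step, holds it or reverses it remains open. Also open, going by these compounds, is how a chain ending in an amine or a carboxylic acid would read out.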